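The compounds below may be only part of what the source reports. "The series", "measured", "known", "first", "only" and "open" are said of these compounds alone.

Of the compounds shown here, three have so far been tested in a functional assay on U-251 cells (Homo sapiens) for inhibition, read by sulforhodamine B assay, with a stated time of 48 h; on this read-out higher numbers stand for weaker inhibition of growth and lower numbers for stronger inhibition of growth. Compound 1 `C=C(C)[C@@H]1CC=C(Cn2cc(COc3cccc(C4NC(=O)NC(C)=C4C(=O)OCC)c3)nn2)CC1` gives 12200 nM in this assay. Compound 2 `C=C(C)[C@@H]1CC=C(Cn2cc(COc3cc(C4NC(=O)NC(C)=C4C(=O)OCC)ccc3OC)nn2)CC1` differs from compound 1 in a single place, (methoxy in place of hydrogen on an aromatic carbon). In this assay compound 2 gives 98100 nM; that single change brought an 8.0-fold higher number from compound 1 to compound 2 (0.91 log units; beyond the scatter). Compound 3 `C=C(C)[C@@H]1CC=C(Cn2cc(COc3ccc(C4NC(=O)NC(C)=C4C(C)=O)cc3)nn2)CC1` is built on another core, and the difference between the two cores is not broken down here; in this assay compound 3 gives 20000 nM. Compound 4 `C=C(C)[C@@H]1CC=C(Cn2cc(COc3ccc(C4NC(=O)NC(C)=C4C(C)=O)cc3OC)nn2)CC1` has not yet been measured. It differs from compound 3 by methoxy in place of hydrogen on an aromatic carbon. Among the measured compounds shown here, this is the same kind of change as the one from compound 1 to compound 2, though the surroundings are not identical: in compound 2 the methoxy sits para to a large group, whereas in compound 4 it sits meta to a large group. The earlier step, an 8.0-fold higher number from compound 1 to compound 2 (0.91 log units; beyond the scatter), is the basis for what is expected here. For compound 4 a rise of similar size is expected, a 5.0-fold higher number from compound 3 to compound 4 (0.70 log units; beyond the scatter). Compound 4 is therefore expected to give about 100000 nM in this assay, most likely between 40000 nM and 250000 nM.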

Compound 4, concentration for total growth inhibition: 77900 nM
For compound 4 the middle estimate is 1.3-fold (0.11 log units) above the measured one; low and high end bracket the measured number.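

In this assay, methoxy in place of hydrogen on an aromatic carbon brought a 3.9-fold higher number from compound 3 to compound 4 (0.59 log units; beyond the scatter), which means weaker inhibition of growth on this core as well. Set side by side, the two steps point the same way, and their sizes cannot be told apart: the same change on two cores in this assay, an 8.0-fold higher number (0.91 log units; beyond the scatter) from compound 1 to compound 2 and a 3.9-fold higher number (0.59 log units; beyond the scatter) from compound 3 to compound 4, 2.1-fold (0.31 log units) apart, within the scatter of two such steps. Among the compounds shown here, this suggests that the change carries over between these two cores, but it rests on only two pairs of compounds in one kind of cell, with the methoxy in surroundings that are not identical, so it neither predicts the outcome on other cores nor explains why the number rises.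

The compounds shown leave open whether hydroxy, fluorine or a longer ether such as ethoxy on that aromatic carbon would bring a similar step. Going by these compounds, it also remains open whether the methoxy step would hold with a carboxylic acid or an amide in place of the ester of compound 1 or the ketone of compound 3.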